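Chloro Substitution on Inactive Styryl Ketone Anilinothiazoles

A few compounds are considered here, and "the series" means these few. Any claim that something is new, unique, unknown or untested is made for them only; others in the source may bear on it.

Compound 3 `COc1cc(/C=C/C(=O)c2sc(Nc3ccccc3)nc2C)cc(OC)c1OC` was examined in a functional assay on PC-3 cells (Homo sapiens) for cytotoxicity, read by MTT assay; on this read-out lower numbers stand for stronger inhibition and higher numbers for weaker inhibition. In this assay compound 3 gives only a limit, > 25000 nM. Compound 1 `COc1cc(/C=C/C(=O)c2sc(Nc3ccc(Cl)cc3)nc2C)cc(OC)c1OC` carries chloro in place of hydrogen on an aromatic carbon. In this assay compound 1 likewise gives only a limit, > 25000 nM. The step that the two limits leave unreadable from compound 3 to compound 1 cannot be read due to the limit of > 25000 nM in this assay, at which 3 of the 3 values shown sit. Compound 2 `Cc1nc(Nc2ccccc2)sc1C(=O)/C=C/c1ccccc1` has another core; the difference between the two cores is not broken down here. In this assay compound 2 gives only a limit, > 25000 nM. Compound 4 `Cc1nc(Nc2ccccc2)sc1C(=O)/C=C/c1ccccc1Cl`, not yet measured, shows (chloro in place of hydrogen on an aromatic carbon). This is the same kind of change as that from compound 3 to compound 1, but the place differs: ortho to a large group rather than para to a large group. The step that the limit leaves unreadable from compound 2 to compound 4 is expected to be near zero, resting on the unreadable earlier step that the two limits leave unreadable from compound 3 to compound 1. Compound 4 is therefore estimated at 35000 nM, between 8000 nM and 150000 nM.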

Compound 4, half-maximal inhibitory concentration: > 25000 nM
Compound 4: no number, only a limit; the forecaster's own chance of this, stated with the estimate: 80%; the middle value does not contradict the limit.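

No step can be read from compound 2 to compound 4 in this assay, due to the shared limit: the limit of > 25000 nM in this assay, at which 4 of the 4 values shown sit.

The compounds shown leave open whether chloro in place of hydrogen on an aromatic carbon changes inhibition at all, as none of them gives a number.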